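The source may report more compounds than this note shows. Statements on the series, on what has been measured and on what is new or still open speak of the compounds shown alone.

Measured so far:
- compound 1, `COc1cc(Nc2nc3ccccc3nc2S(=O)(=O)c2ccccc2)cc(OC)c1OC`: 1770 nM
- compound 2, `COc1cc(Nc2nc3ccccc3nc2S(=O)(=O)c2ccc(C)cc2)cc(OC)c1`: 20 nM

In a functional assay on HL-60 cells (Homo sapiens) for cytotoxicity, read by MTT assay, with a stated time of 72 h (on this read-out higher numbers stand for weaker inhibition and lower numbers for stronger inhibition), compound 2 gives 20 nM, the lowest of the two numbers; compound 1, differing from it in two places at once, gives 1770 nM. Compound 3, `COc1cc(Nc2nc3ccccc3nc2S(=O)(=O)c2ccc(C)cc2)cc(OC)c1OC`, changes compound 2 by methoxy in place of hydrogen on an aromatic carbon. Among the compounds with values here, no single step of this kind has been measured. Since compound 1, which also carries three methoxy groups, shows the higher number, a rise in the number, beyond the scatter, is expected from compound 2 to compound 3 of a 10-fold higher number from compound 2 to compound 3 (1.00 log units; beyond the scatter). Compound 3 is therefore estimated at 200 nM, within 30 nM to 1500 nM.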

Compound 3, half-maximal inhibitory concentration: 320 nM
Compound 3: the middle estimate sits 1.6-fold (0.20 log units) below what was measured; low and high end bracket the measured number.
By their numbers in this assay, from the lowest: compound 2; then compound 3; then compound 1.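

In this assay, a methoxy in place of hydrogen, ortho to two methoxy groups and para to a large group, is a large change for the worse, giving a 16-fold higher number from compound 2 to compound 3 (1.20 log units; beyond the scatter) on this otherwise unchanged core. The other change, an added methyl, moves the number the opposite way, with a 5.5-fold lower number from compound 1 to compound 3 (0.74 log units; beyond the scatter) among compounds that carry all three methoxy groups. Nothing available explains either step. On these data alone, whether a hydroxyl, an ethoxy or an amine at the methoxy's position would also raise the number stays open.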